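A few compounds are considered here, and "the series" means these few. Any claim that something is new, unique, unknown or untested is made for them only; others in the source may bear on it.

Compound 2 `COc1cc(-c2ccnc3cc(-c4ccc(C)cc4)nn23)cc(OC)c1OC` holds the lowest number of the three measured compounds in a functional assay on A549 cells (Homo sapiens) for inhibition, read by CCK-8 assay, with a stated time of 48 h (on this read-out lower numbers stand for stronger inhibition and higher numbers for weaker inhibition), where compound 2 gives 3 nM. Compound 1 `COc1ccc(-c2cc3nccc(-c4cc(OC)c(OC)c(OC)c4)n3n2)cc1N` gives 138 nM in this assay, and compound 3 `COc1cc(-c2ccnc3cc(-c4ccc5ccn(C)c5c4)nn23)cc(OC)c1OC` gives 829 nM. The two steps from compound 2 mark the span: a 46-fold lower number from compound 1 to compound 2 (1.66 log units; beyond the scatter), and a 280-fold higher number from compound 2 to compound 3 (2.44 log units; beyond the scatter). Compound 4 `COc1cc(-c2ccnc3cc(-c4ccc(-c5cnn(C)c5)cc4)nn23)cc(OC)c1OC` has not yet been measured; it differs from compound 2 by 1-methyl-1H-pyrazol-4-yl in place of methyl on an aromatic carbon. The step that bears most directly on this change is the exchange of the 4-methylphenyl of compound 2 for a larger aromatic group, a 280-fold higher number from compound 2 to compound 3 (2.44 log units; beyond the scatter), a large loss. The other variant at the same place, compound 1, also sits far above compound 2, as a 46-fold lower number from compound 1 to compound 2 (1.66 log units; beyond the scatter) shows. Both measured alternatives to 4-methylphenyl give weaker inhibition, so a higher number is expected for compound 4 in this assay. Within the data shown here, compound 4, however, keeps the whole six-membered ring of compound 2 and only extends it, so the step is expected to be smaller than the one to compound 3. Compound 4 is therefore expected to give 40 nM, within 8 nM to 300 nM, an expected step of a 13-fold higher number from compound 2 to compound 4 (1.12 log units; beyond the scatter).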

Compound 4, half-maximal inhibitory concentration: 1150 nM
The estimate for compound 4 lay 29-fold (1.46 log units) below the measured number; measured number above the stated range.
By their numbers in this assay, from the lowest: compound 2; then compound 1; then compounds 3 and 4 (each within the scatter of the next).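

In this assay, the step of a 380-fold higher number from compound 2 to compound 4 (2.58 log units; beyond the scatter) shows that keeping the benzene ring of compound 2 does not protect the low number: a change only at the methyl, on an aromatic carbon para to a large group, is enough to lose it. The earlier compounds shown here could not show this, since compound 1 and compound 3 each replace the whole 4-methylphenyl group. Compound 4 and compound 3 also lie within the usual scatter of each other, so two quite different groups end at the same level, and no evidence is available to explain the loss at this position.

The compounds shown hold nothing intermediate between methyl and 1-methyl-1H-pyrazol-4-yl at this place, so it remains open whether an ethyl, a methoxy or a chlorine would stay close to compound 2, which gives 3 nM. As far as these compounds go, it is also open whether a plain phenyl or a pyridine ring in place of the 1-methyl-1H-pyrazol-4-yl of compound 4 would give a similar number, which would show whether the loss depends on this particular ring.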